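A few compounds are considered here, and "the series" means these few. Any claim that something is new, unique, unknown or untested is made for them only; others in the source may bear on it.

Series notes. Compound 1 (`ClCc1ccccc1Cn1cnc2c(Cl)nc(Cl)nc21`) has no result in a functional assay on A549 cells (Homo sapiens) for cytotoxicity, read by sulforhodamine B assay, with a stated time of 48 h; a lower number here means that less compound is tolerated, a higher number that more compound is tolerated; compound 1 stands at "not determined" (no result reported). Compound 2 (`ClCc1ccccc1Cn1cnc2ncnc(Cl)c21`) reaches only a limit of this assay, compound 2 sitting at > 100000 nM. Compound 2 therefore stands on no single number but at the limit of > 100000 nM in this assay, at which 1 of the 2 values shown sits, and the remaining entry carries none. Compound 3 (`ClCc1ccccc1Cn1cnc2nc(Cl)nc(Cl)c21`) differs from compound 2 by chloro in place of hydrogen on an aromatic carbon. For the measured compounds named here, no step between measured compounds exists, so nothing beyond the scatter is expected in this assay in either direction. Compound 3 is estimated at 100000 nM, range 30000 nM to 300000 nM. The expected step of a number no higher from compound 2 to compound 3 (the limit leaves the size open) is flat.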

Compound 3, concentration lethal to 50% of the cells: > 100000 nM
Compound 3 was reported as a limit (the forecaster's own chance of this, stated with the estimate: 70%); the middle value sits exactly at the limit.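

Compound 2 and compound 3 both end as limits in this assay, and no step between them can be read: the limit of > 100000 nM in this assay, at which 2 of the 3 values shown sit.

The compounds shown leave open whether chloro in place of hydrogen on an aromatic carbon changes this read-out at all.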